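The source may report more compounds than this note shows. Statements on the series, on what has been measured and on what is new or still open speak of the compounds shown alone.

- compound 1 `CC1(c2nc(-c3ccc(CNC(=O)[C@H]4NCC[C@@H]4O)cc3)no2)CCCCC1`: > 50 ug/mL
- compound 2 `CCCCCCCc1nc(-c2ccc([C@H](C)NC(=O)[C@H]3NCC[C@@H]3O)cc2)no1`: 27 ug/mL
- compound 3 `CCCCCc1nc(-c2ccc(CNC(=O)[C@H]3NCC[C@@H]3O)cc2)no1`: not yet measured

In a physicochemical assay for solubility, at pH 7.4 (a lower number here means a less soluble compound, a higher number a more soluble compound), compound 1 gives > 50 ug/mL, which is a limit of the assay and not a number. Its true position is therefore open, and any comparison with it stays loose.

Compound 3 keeps the core of compound 1 and makes one change: pentyl in place of 1-methylcyclohexyl on an aromatic carbon. Among the measured compounds shown here, no measured pair shows this change, so the guide is indirect. Compound 2, which also carries an open chain with no ring at this place, gives 27 ug/mL in this assay, though it differs elsewhere too.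

A small drop, or none beyond the scatter, is expected in this assay: the estimated step is an at least 1.1-fold lower number from compound 1 to compound 3 (0.04 log units; that floor lies within the scatter). For compound 3 the expected value is 45 ug/mL, with an estimated range from 20 ug/mL to 100 ug/mL.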

Compound 3, solubility: > 50 ug/mL
Compound 3: only a limit was reported (the forecaster's own chance of this, stated with the estimate: 45%); middle value at least 1.1-fold (0.04 log units) from the limit.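

No step from compound 1 to compound 3 can be read, because both compounds stop at the same limit of the assay and neither gives an actual number: the limit of > 50 ug/mL in this assay, at which 2 of the 3 values shown sit.

The compounds shown leave open where compound 1 and compound 3 truly stand in this assay, and whether pentyl in place of 1-methylcyclohexyl moves the number at all.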